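Working notes: from compound 3 to compound 4

The source may report more compounds than this note shows. Statements on the series, on what has been measured and on what is new or still open speak of the compounds shown alone.

Measured in a functional assay on DU-145 cells (Homo sapiens) for cytotoxicity, read by MTT assay (on this read-out higher numbers stand for weaker inhibition and lower numbers for stronger inhibition), for three compounds:
- compound 1 (`CC(=O)OCCC(=O)O[C@H](CC=C(C)C)C1=CC(=O)c2c(O)ccc(O)c2C1=O`) at 15700 nM
- compound 2 (`CC(C)=CC[C@@H](OCCO)C1=CC(=O)c2c(O)ccc(O)c2C1=O`) at 9900 nM
- compound 3 (`CC(C)=CC[C@@H](OC(=O)C1CCCCO1)C1=CC(=O)c2c(O)ccc(O)c2C1=O`) at 24700 nM

The measured step of a 1.6-fold higher number from compound 1 to compound 3 (0.20 log units; within the scatter) stays within the scatter, whereas a 2.5-fold higher number from compound 2 to compound 3 (0.40 log units; beyond the scatter) goes beyond it, so compound 3 stands clear only of compound 2.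

The open step to compound 4 (`CCC(CO[C@H](CC=C(C)C)C1=CC(=O)c2c(O)ccc(O)c2C1=O)OC`) is 2-methoxybutyl in place of (oxan-2-yl)carbonyl on an oxygen on a saturated carbon and takes the carbonyl off that oxygen. Compound 2 also has a chain without a carbonyl on that oxygen, namely 2-hydroxyethyl, which makes the modest 2.5-fold higher number from compound 2 to compound 3 (0.40 log units; beyond the scatter) the closest guide when read in reverse. The other exchange of this kind, a 1.6-fold lower number from compound 1 to compound 2 (0.20 log units; within the scatter), points the same way but stays within the scatter. Within the data shown here, no measured compound carries 2-methoxybutyl, so the guide is loose.

The estimated move in this assay is modest and towards a lower number (a 2.1-fold lower number from compound 3 to compound 4 (0.31 log units; beyond the scatter)). For compound 4 the estimated value is 12000 nM (expected range 5500 nM to 26000 nM).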

Compound 4, half-maximal inhibitory concentration: 45700 nM
Estimate against measurement, compound 4: 3.8-fold (0.58 log units) below, and the stated range ends below it.
By their numbers in this assay, from the lowest: compounds 2, 1, 3 and 4 (each within the scatter of the next, the first and the last beyond it).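

Removing the carbonyl from that oxygen does not by itself lower the number in this assay: compound 4 lacks it, yet the change from (oxan-2-yl)carbonyl to 2-methoxybutyl stays within the scatter (a 1.9-fold higher number from compound 3 to compound 4 (0.27 log units; within the scatter)). The two chains without a carbonyl also stand clearly apart (a 4.6-fold higher number from compound 2 to compound 4 (0.66 log units; beyond the scatter)), so the earlier link between compound 2 and its carbonyl-free chain does not extend to 2-methoxybutyl, and compound 4 also stands clear of the ester compound 1 (a 2.9-fold higher number from compound 1 to compound 4 (0.46 log units; beyond the scatter)). Nothing available explains these differences.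

The compounds shown do not separate the terminal hydroxyl of 2-hydroxyethyl from the chain length and branching of 2-methoxybutyl, which 2-methoxyethyl or 4-hydroxybutyl would help to resolve. On these data alone, the response to a chain ending in an amine or a carboxylic acid also remains open.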